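The source may report more compounds than this note shows. Statements on the series, on what has been measured and on what is new or still open speak of the compounds shown alone.

Compound 2 `COC(=O)CCC(=O)N(O)c1cccc(OCc2ccc3ccccc3n2)c1` is the reference point of this set. In an assay on isolated protein for inhibition of Polyunsaturated fatty acid 5-lipoxygenase (Rattus norvegicus) (a higher number here means a weaker inhibitor, a lower number a stronger inhibitor), compound 2 gives 1400 nM, the lowest of the three numbers measured. Its closest neighbour is compound 3 `COC(=O)CC(=O)Nc1cccc(OCc2ccc3ccccc3c2)c1`, which in this assay gives 9500 nM; compound 3 differs from compound 2 in more than one place, so only the two values themselves can be compared. The furthest is compound 1 `COC(=O)CCC(=O)Nc1cccc(OCc2ccc3ccccc3n2)c1`, which in this assay gives 28000 nM.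

The step now followed leads from compound 2 to compound 4 `COC(=O)CCC(=O)N(C)c1cccc(OCc2ccc3ccccc3n2)c1`, a change described as methyl in place of hydroxy on an amide-type nitrogen. Within the data shown here, the one measured step that bears on this position is the one from compound 1 to compound 2, where hydroxy replaced hydrogen on the same amide-type nitrogen and the result was a 20-fold lower number from compound 1 to compound 2 (1.30 log units; beyond the scatter). Compound 4 takes that hydroxy away again and puts a methyl in its place. Among the measured compounds shown here, since the single available comparison shows that the hydroxy at this nitrogen went with the large gain, removing it is expected to give back most of that gain, so the number for compound 4 is estimated to rise, with an expected step of a 14-fold higher number from compound 2 to compound 4 (1.15 log units; beyond the scatter). Compound 4 is therefore expected to give about 20000 nM in this assay, within a range from 5000 nM to 60000 nM.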

Compound 4, half-maximal inhibitory concentration: 14000 nM
For compound 4 the middle estimate is 1.4-fold (0.15 log units) above the measured one, within the range that was stated.
By their numbers in this assay, from the lowest: compound 2; then compounds 3, 4 and 1 (each within the scatter of the next, the first and the last beyond it).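

The step from compound 1 to compound 2 showed only that hydroxy on this amide-type nitrogen went with a lower number than hydrogen, leaving open whether any single heavy atom there would do the same. Compound 4 answers this for methyl: in this assay the change from hydroxy to methyl gives (a 10-fold higher number from compound 2 to compound 4 (1.00 log units; beyond the scatter)), while methyl in place of hydrogen gives ((a 2.0-fold lower number from compound 1 to compound 4 (0.30 log units; within the scatter))), so among these three groups only hydroxy stands apart, and simply having a group other than hydrogen on this nitrogen does not bring the gain. Hydroxy brings a hydrogen-bond donor and a hydrogen-bond acceptor that methyl lacks, but no measurement at hand says what lies behind the difference.

Going by these compounds, what a methoxy group or an amino group on this nitrogen would give remains open, and either would show whether the gain holds beyond hydroxy itself. An ethyl group or a longer chain in the same place is also unexplored, as is whether hydroxy brings a similar gain on a different core.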